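The source may hold more compounds than are shown below. What is called first, only, known or untested is meant among the compounds shown, and "the series" means these compounds.

Compound 1 `CON=C1CCC(CN2CCN(c3nc(=O)c4cc(C(F)(F)F)cc([N+](=O)[O-])c4s3)[C@@H](C)C2)CC1`, compound 2 `CCON=C1CCC(CN2CCN(c3nc(=O)c4cc(C(F)(F)F)cc([N+](=O)[O-])c4s3)[C@@H](C)C2)CC1` and compound 3 `CON=C1CCC(CN2CCN(c3nc(=O)c4cc(C(F)(F)F)cc([N+](=O)[O-])c4s3)CC2C)CC1` were tested in an ADME assay on Vero cells (Chlorocebus sabaeus) for cytotoxicity (on this read-out lower numbers stand for higher toxicity in this test and higher numbers for lower toxicity in this test), where a limit rather than a number was reached each time. Compound 1 gives > 64 ug/mL, which is a limit of the assay. Compound 2 gives > 64 ug/mL, again a limit. Compound 3 gives > 64 ug/mL, also a limit. Compound 2 differs from compound 1 by methyl in place of hydrogen on a saturated chain carbon bound to an oxygen on an unsaturated carbon; the two limits leave the step that the two limits leave unreadable from compound 1 to compound 2 unreadable in size. The difference between the cores of compound 1 and compound 3 is not broken down here.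

Compound 4 `CCON=C1CCC(CN2CCN(c3nc(=O)c4cc(C(F)(F)F)cc([N+](=O)[O-])c4s3)CC2C)CC1`, not yet measured in this assay, stands to compound 3 as compound 2 stands to compound 1: the change is methyl in place of hydrogen on a saturated chain carbon bound to an oxygen on an unsaturated carbon, the same change at the same place. Because (the limit of > 64 ug/mL in this assay, at which 3 of the 3 values shown sit), compound 4 is expected to sit at that limit as well. The expected step that the limit leaves unreadable from compound 3 to compound 4 is thus estimated as unreadable in the same way. Compound 4 is expected to give about 100 ug/mL, plausibly between 50 ug/mL and 250 ug/mL.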

Compound 4, half-maximal cytotoxic concentration: > 64 ug/mL
Compound 4: only a limit was reported; the forecaster's own chance of this, stated with the estimate: 85%; the middle value is on the limit's open side.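

For the compounds shown here, compound 3 and compound 4 each reached only a limit in this assay, so no step between them can be read. The compounds shown leave open where any of their actual cytotoxic concentrations lies, and whether going from methoxy to ethoxy changes it at all: the limit of > 64 ug/mL in this assay, at which 4 of the 4 values shown sit.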